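Swapping a Naphthylmethyl Thioether for a Chlorobenzyl Thioether

The source may report more compounds than this note shows. Statements on the series, on what has been measured and on what is new or still open speak of the compounds shown alone.

compound 1: `Cc1cc(-c2ccccc2)n(/C(N)=N/S(=O)(=O)c2cc(C)c(Cl)cc2SCc2cccc3ccccc23)n1` — 12000 nM
compound 2: `Cc1cc(S(=O)(=O)/N=C(\N)n2nccc2-c2ccccc2)c(SCc2cccc(Cl)c2)cc1Cl` — 10000 nM
compound 3: `Cc1cc(-c2ccccc2)n(/C(N)=N/S(=O)(=O)c2cc(C)c(Cl)cc2SCc2ccccc2)n1` — 10000 nM

Of the compounds shown here, three sharing a sulfonyl-guanidine core have been tested in an ADME assay on HaCaT cells (Homo sapiens) for cytotoxicity, read by MTT assay, with a stated time of 72 h; a lower number here means a stronger inhibitor, a higher number a weaker inhibitor. Compound 1 carries the largest of the three numbers on paper, but its gap to compound 2 and its step to compound 3 are both within the scatter, so the three cannot be told apart. Within the data shown here, the one matched step, a 1.2-fold lower number from compound 1 to compound 3 (0.08 log units; within the scatter), changes the same position that is changed here and moves nothing beyond the scatter.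

Compound 4, `Cc1cc(-c2ccccc2)n(/C(N)=N/S(=O)(=O)c2cc(C)c(Cl)cc2SCc2cccc(Cl)c2)n1`, differs from compound 1 by 3-chlorophenyl in place of naphthalen-1-yl on a saturated chain carbon bound to a sulfur. Compound 2 already carries a 3-chlorobenzyl thioether on a related core and gives 10000 nM in this assay, again indistinguishable from compound 1. Among the measured compounds shown here, with the only relevant step being flat, the expected step of a 1.2-fold lower number from compound 1 to compound 4 (0.08 log units; within the scatter) is none beyond the scatter. Compound 4 is therefore estimated at 10000 nM, with a range from 5000 nM to 20000 nM.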

Compound 4, half-maximal inhibitory concentration: 18000 nM
For compound 4 the middle estimate is 1.8-fold (0.26 log units) below the measured one; the range from low to high includes it.
By their numbers in this assay, from the lowest: compounds 2, 3, 1 and 4 (each within the scatter of the next).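

In this assay, among these compounds, the larger step at this position so far, 3-chlorophenyl in place of naphthalen-1-yl on a saturated chain carbon bound to a sulfur (a 1.5-fold higher number from compound 1 to compound 4 (0.18 log units; within the scatter)), still lies within the scatter, so the number does not separate a chlorinated single ring from the two-ring naphthalen-1-yl group. Two further single-place changes, chloro in place of hydrogen on an aromatic carbon (a 1.8-fold higher number from compound 3 to compound 4 (0.26 log units; within the scatter)) and methyl in place of hydrogen on an aromatic carbon (a 1.8-fold higher number from compound 2 to compound 4 (0.26 log units; within the scatter)), also stay within the scatter, leaving all four compounds indistinguishable. Nothing available bears on this result.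

Every group shown at this position is aromatic and carbon-ringed, so the compounds leave open whether an amine or a carboxylic acid in place of the 3-chlorophenyl would give a step beyond the scatter. They also leave open what a longer chain to the sulfur would do.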